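This account rests on a few compounds, and the source may have more. Where it says the series, first, only, none or still open, it means among the compounds named here.

Series notes. Compound 1 `COC(=O)CC1c2ccccc2N=C(N2CCCCC2)N1C1CCCCC1` is the reference; in a functional assay on cells (Oocyte) for inhibition of Voltage-dependent T-type calcium channel subunit alpha-1H (Homo sapiens), tested at 100 uM (a lower number here means less inhibition, a higher number more inhibition at the concentration tested (going by the name of the read-out)), compound 1 gives 27%. Compound 2 `COC(=O)CC1c2ccccc2N=C(N2CCOCC2)N1C1CCCCC1` carries one change: morpholin-4-yl in place of piperidin-1-yl on a carbon with a double bond to nitrogen. The step of a number 14.8 percentage points lower from compound 1 to compound 2 (beyond the scatter) is beyond the scatter, and in this assay compound 2 gives 12.2%. Compound 3 `O=C(O)CC1c2ccccc2N=C(N2CCCCC2)N1c1ccccc1` differs from compound 1 in more than one place; the difference between the two cores is not broken down here. In this assay compound 3 gives 8%, within the scatter of compound 2 and beyond it from compound 1.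

Compound 4 `O=C(O)CC1c2ccccc2N=C(N2CCOCC2)N1c1ccccc1`, not yet measured, carries the same kind of change from compound 3: morpholin-4-yl in place of piperidin-1-yl on a carbon with a double bond to nitrogen. The surroundings differ: here the carbon is next to the ring atom that bears a phenyl group and two ring bonds from the ring atom that bears a carboxymethyl group, whereas in compound 1 the carbon is next to the ring atom that bears a cyclohexyl group and two ring bonds from the ring atom that bears a (methoxycarbonyl)methyl group.

Compound 3 starts low, so the expected step is smaller than the earlier one and within the scatter, a number 5 percentage points lower from compound 3 to compound 4 (within the scatter), because compound 3 already gives only 8%. For compound 4 the estimate in this assay is 3%, between -8% and 14%.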

Compound 4, a percentage reported as inhibition, at one concentration (the size of the read-out at that concentration, not a potency): 9%
The estimate for compound 4 lay 6 percentage points below the measured number; low and high end bracket the measured number.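

The change from piperidin-1-yl to morpholin-4-yl does not carry over at the same size between the two cores in this assay: the same change on two cores in this assay, a number 14.8 percentage points lower (beyond the scatter) from compound 1 to compound 2 and a number 1 percentage points higher (within the scatter) from compound 3 to compound 4, 15.8 percentage points apart, beyond the scatter of two such steps. On the core of compound 3 the step reads a number 1 percentage points higher from compound 3 to compound 4 (within the scatter), so the drop seen on the core of compound 1 cannot be assumed for another core in this series. This does not show what sets the two cores apart: they differ in more than one place, a cyclohexyl group against a phenyl group and a (methoxycarbonyl)methyl group against a carboxymethyl group, and one pair per core cannot single out either difference.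

The compounds shown leave open which of these two differences governs the step, a question that a core pairing cyclohexyl with carboxymethyl, or phenyl with (methoxycarbonyl)methyl, would address. They also leave open how other amines at the same carbon would behave on either core, such as piperazin-1-yl or an open-chain dimethylamino group.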